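Aryl swap on the ring amine: estimating compound 4

The source may report more compounds than this note shows. Statements on the series, on what has been measured and on what is new or still open speak of the compounds shown alone.

Measured compounds:
compound 1 `COc1cccc(N2CCN(C(=O)c3oc(C)nc3-c3ccccc3F)CC2)c1`: 56.1 nM
compound 2 `Cc1ccc(C)c(N2CCN(C(=O)c3oc(C)nc3-c3ccccc3F)CC2)c1`: 319 nM
compound 3 `Cc1ccc(C)c(N2CCN(C(=O)c3oc(C)nc3-c3ccc(Cl)cc3)CC2)c1`: "not active" (no number reported)

In a functional assay on HL-60 cells (Homo sapiens) for inhibition, read by MTT assay, with a stated time of 72 h (on this read-out lower numbers stand for stronger inhibition and higher numbers for weaker inhibition), compound 1 gives 56.1 nM. For the measured compounds named here, compound 2 gives 319 nM, the highest of the two numbers in hand; its nearest neighbour is compound 1, and the only counted step between measured compounds is a 5.7-fold higher number from compound 1 to compound 2 (0.75 log units; beyond the scatter), a modest change that lies beyond the scatter. Compound 3 is reported as "not active" (no number reported), without a number; it differs from compound 2 elsewhere in the structure, so that pair says nothing about the ring amine.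

Compound 4 `Cc1nc(-c2ccccc2F)c(C(=O)N2CCN(c3cccc(Cl)c3)CC2)o1` differs from compound 2 by 3-chlorophenyl in place of 2,5-dimethylphenyl on an amine nitrogen in a ring. Going by the values given here, the one bearing step, a 5.7-fold higher number from compound 1 to compound 2 (0.75 log units; beyond the scatter), shows a higher number when the 2,5-dimethylphenyl replaced the 3-methoxyphenyl. Compound 4 returns to a phenyl carrying a single substituent, though 3-chlorophenyl is not 3-methoxyphenyl, so the step size is uncertain. A lower number is expected for compound 4, estimated as a 3.2-fold lower number from compound 2 to compound 4 (0.50 log units; beyond the scatter). The estimate for compound 4 is 100 nM, ranging from 30 nM to 350 nM.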

Compound 4, half-maximal inhibitory concentration: 39.4 nM
For compound 4 the middle estimate is 2.5-fold (0.40 log units) above the measured one, within the range that was stated.
By their numbers in this assay, from the lowest: compounds 4 and 1 (each within the scatter of the next); then compound 2.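

In this assay, the change from 2,5-dimethylphenyl to 3-chlorophenyl on the ring amine gives an 8.1-fold lower number from compound 2 to compound 4 (0.91 log units; beyond the scatter) and is the second step at this position, so the higher number of compound 2 now stands against two phenyl groups with a single substituent, not just one. Chloro in place of methoxy on the aromatic carbon gives a 1.4-fold lower number from compound 1 to compound 4 (0.15 log units; within the scatter) and separates neither group from the other, so this position tolerates either substituent in compound 1 and compound 4 alike. No measurement shown accounts for the gap between these aryl groups.

As far as these compounds go, it remains open whether an unsubstituted phenyl, or a phenyl carrying an amine or a carboxylic acid, would match 3-chlorophenyl. Compound 3 also leaves open whether its aryl group on the shared core would give "not active" alongside 3-chlorophenyl.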